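Demethylation of the piperazine amine: cytotoxicity notes

The compounds below may be only part of what the source reports. "The series", "measured", "known", "first", "only" and "open" are said of these compounds alone.

Compound 2 `CN1CCN(c2ccc3[nH]c(=O)nc(-c4ccccc4)c3c2)CC1` carries a 4-methylpiperazin-1-yl group on the shared core. In an ADME assay on L6 cells (Rattus norvegicus) for cytotoxicity, read by fluorescence and resazurin assay, with a stated time of 72 h (a lower number here means that less compound is needed, a higher number that more compound is needed for the effect), compound 2 gives only a limit, > 50000 nM. Compound 1 `O=c1nc(-c2ccccc2)c2cc(-c3cn[nH]c3)ccc2[nH]1` carries 1H-pyrazol-4-yl at the same aromatic carbon. In this assay compound 1 likewise gives only a limit, > 50000 nM. The step that the two limits leave unreadable from compound 1 to compound 2 therefore cannot be sized; both values rest at the limit of > 50000 nM in this assay, at which 2 of the 2 values shown sit.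

Compound 3 `O=c1nc(-c2ccccc2)c2cc(N3CCNCC3)ccc2[nH]1` differs from compound 2 by hydrogen in place of methyl on an amine nitrogen in a ring; cut one bond further out, 4-methylpiperazin-1-yl becomes piperazin-1-yl. Within the data shown here, no measured step bears on this change: the only step between measured compounds is unreadable, and both measured values sit at a limit. No step beyond the scatter is expected in this assay. Compound 3 is expected to remain at the limit, estimated at 80000 nM within 40000 nM to 200000 nM, the expected step being a step that the limit leaves unreadable from compound 2 to compound 3.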

Compound 3, half-maximal effective concentration: > 25000 nM
Compound 3: a limit, no number; the forecaster's own chance of this, stated with the estimate: 90%; the middle value does not contradict the limit.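

In this assay compound 3 gives only a limit, > 25000 nM. Among these compounds, no step between compound 3 and compound 1 or compound 2 can be read. The compounds shown leave open what concentration of any of the three reaches the half-maximal effect in this assay, and whether hydrogen in place of methyl on the ring nitrogen changes it.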